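Removing the chloro from compound 2

The source may hold more compounds than are shown below. What is called first, only, known or untested is meant among the compounds shown, and "the series" means these compounds.

compound 1 `Cc1cn(C2CCN(Cc3cccc(Oc4ccccc4)n3)CC2)c(=O)[nH]c1=O`: > 64000 nM
compound 2 `Cc1cn(C2CCN(Cc3cc(Oc4cccc(Cl)c4)ccn3)CC2)c(=O)[nH]c1=O`: > 64000 nM
compound 3 `Cc1cn(C2CCN(Cc3cncc(Oc4cccc(OC(F)(F)F)c4)c3)CC2)c(=O)[nH]c1=O`: > 64000 nM

All three entries come from an ADME assay on MRC5 cells (Homo sapiens) for cytotoxicity, read by fluorescence and resazurin assay, with a stated time of 3 days (on this read-out higher numbers stand for weaker inhibition and lower numbers for stronger inhibition), and each is a limit, not a number. Among the compounds with values here, the series so far shows (the limit of > 64000 nM in this assay, at which 3 of the 3 values shown sit). For compound 2 the entry > 64000 nM is such a limit, so compound 2 stands with the other two compounds and cannot be ranked against them.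

Compound 4 `Cc1cn(C2CCN(Cc3cc(Oc4ccccc4)ccn3)CC2)c(=O)[nH]c1=O` differs from compound 2 in one place: hydrogen in place of chloro on an aromatic carbon. This is hydrogen in place of chloro on an aromatic carbon, so 3-chlorophenoxy becomes phenoxy. Within the data shown here, no measured pair differs in one place only, so no measured step is available as a guide.

Compound 1, which also carries a phenoxy group, gives > 64000 nM, a limit. On that basis, no step beyond the scatter is expected in this assay, and no direction is favoured. The estimated change is a number no higher from compound 2 to compound 4 (the limit leaves the size open). A limit is again the most likely kind of result. For compound 4 the expected value is 64000 nM, with an estimated range from 30000 nM to 100000 nM.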

Compound 4, half-maximal inhibitory concentration: > 64000 nM
Compound 4 was reported as a limit; the forecaster's own chance of this, stated with the estimate: 85%; the middle value sits exactly at the limit.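

Compound 2 and compound 4 are both reported as limits, so no step can be read between them. The same holds across the series: the limit of the assay is the only result shown: the limit of > 64000 nM in this assay, at which 4 of the 4 values shown sit.

The compounds shown leave open whether hydrogen in place of chloro on an aromatic carbon shifts the read-out at all.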